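A few compounds are considered here, and "the series" means these few. Any claim that something is new, unique, unknown or untested is made for them only; others in the source may bear on it.

Measured in an in vitro ADME assay on microsomes from liver (Homo sapiens) for metabolic stability; on this read-out lower numbers stand for slow clearance and higher numbers for fast clearance:
- compound 1 `Nc1cc(Nc2ccc(Oc3ccc(Cl)cc3)cc2)ncn1` gives < 14 mL.min-1.g-1 (a limit of the assay)
- compound 2 `Nc1nccc(Nc2ccc(Oc3ccc(Cl)cc3)cc2)n1` gives 206 mL.min-1.g-1
- compound 3 `Nc1cccc(Nc2ccc(Oc3ccc(Cl)cc3)cc2)n1` gives 100 mL.min-1.g-1

Compound 3 holds the lower of the two actual numbers, with a 2.1-fold lower number from compound 2 to compound 3 (0.31 log units; beyond the scatter). Compound 4 `Nc1ccnc(Nc2ccc(Oc3ccc(Cl)cc3)cc2)c1` comes next, with 4-aminopyridin-2-yl in place of 6-aminopyridin-2-yl on a nitrogen on an aromatic ring. The steps of an at least 14-fold higher number from compound 1 to compound 2 (1.16 log units; beyond the scatter) and an at least 7.1-fold higher number from compound 1 to compound 3 (0.85 log units; beyond the scatter) show that exchanging this group can matter greatly, so the range stays wide. Compound 4 keeps the ring type of compound 3, and the closest measured step, from compound 2 to compound 3, was only modest. No step beyond the scatter is expected in this assay, the estimate being a 1.3-fold lower number from compound 3 to compound 4 (0.10 log units; within the scatter). For compound 4 the expected value is 80 mL.min-1.g-1, with an estimated range of 25 mL.min-1.g-1 to 220 mL.min-1.g-1.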

Compound 4, intrinsic clearance in microsomes: 14 mL.min-1.g-1
Compound 4: middle estimate off by 5.7-fold (0.76 log units), on the high side; measured number outside the range, below it.
By their numbers in this assay, from the lowest: compound 4; then compound 3; then compound 2.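

In this assay, 4-aminopyridin-2-yl in place of 6-aminopyridin-2-yl on a nitrogen on an aromatic ring gives a 7.1-fold lower number from compound 3 to compound 4 (0.85 log units; beyond the scatter); the counted atoms, donors and acceptors stay the same, so rearranging the group alone can shift this read-out, now within the aminopyridin-2-yl pair as well. The wider comparison gives a 15-fold lower number from compound 2 to compound 4 (1.17 log units; beyond the scatter). The remaining comparison gives a number no lower from compound 1 to compound 4 (the limit leaves the size open), and the size of this step cannot be read: the limit of < 14 mL.min-1.g-1 in this assay, at which 1 of the 4 values shown sits.

On these data alone, whether a methylamino or dimethylamino group in place of the amine of 4-aminopyridin-2-yl would keep this clearance remains open.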